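Tethering the amide substituent into a phenylcyclopropyl ring

This account rests on a few compounds, and the source may have more. Where it says the series, first, only, none or still open, it means among the compounds named here.

Compound 1: `CC[C@H](NC(=O)c1c(CN2CCC(N3CCCCC3)CC2)c(-c2cccc(C(F)(F)F)c2)nc2ccccc12)c1ccccc1` — 6 nM
Compound 2: `CC(C)[C@H](NC(=O)c1c(CN2CCC(N3CCCCC3)CC2)c(-c2cccc(C(F)(F)F)c2)nc2ccccc12)c1ccccc1` — 25 nM

In an assay on cells for antagonist activity at transient receptor potential cation channel subfamily V member 4 (Rattus norvegicus), read by FLIPR and calcium flux, with a stated time of 10 min (on this read-out higher numbers stand for weaker inhibition and lower numbers for stronger inhibition), compound 2 gives the higher of the two numbers measured, its nearest neighbour being compound 1 with a 4.2-fold higher number from compound 1 to compound 2 (0.62 log units; beyond the scatter). Compound 3 `O=C(NC1(c2ccccc2)CC1)c1c(CN2CCC(N3CCCCC3)CC2)c(-c2cccc(C(F)(F)F)c2)nc2ccccc12` carries 1-phenylcyclopropyl in place of 2-methyl-1-phenylpropyl on an amide-type nitrogen. Within the data shown here, the only step that bears on it, from compound 1 to compound 2, was modest, and no measured pair shows the effect of closing the branch into a ring. An outcome close to compound 2 is therefore expected, a 1.3-fold lower number from compound 2 to compound 3 (0.10 log units; within the scatter), with wide uncertainty. For compound 3 the estimate is 20 nM, between 5 nM and 80 nM.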

Compound 3, half-maximal inhibitory concentration: 2.5 nM
For compound 3 the middle estimate is 8.0-fold (0.90 log units) above the measured one; the measured number lies below the stated range.
By their numbers in this assay, from the lowest: compound 3; then compound 1; then compound 2.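

On the amide-type nitrogen, 1-phenylcyclopropyl gave a lower number than either open-chain group in this assay (a 10-fold lower number from compound 2 to compound 3 (1.00 log units; beyond the scatter); a 2.4-fold lower number from compound 1 to compound 3 (0.38 log units; beyond the scatter)). Branching at this position therefore need not raise the number, as the earlier methyl step alone might have suggested. No evidence here accounts for this result. The compounds shown leave open whether the gain belongs to the three-membered ring itself or would persist with 1-phenylcyclobutyl. They also leave open how a fluorine or a methoxy group on its phenyl ring would fare.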